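Fluorophenyl benzyl variation on an aryl-piperazine series

This account rests on a few compounds, and the source may have more. Where it says the series, first, only, none or still open, it means among the compounds named here.

Measured compounds:
- compound 1 `COc1ccccc1N1CCN(CCNC(=O)/N=N/c2ccc(F)cc2)CC1`: 36 nM
- compound 2 `COc1ccccc1N1CCN(CCCNC(=O)/N=N/c2ccc(F)cc2)CC1`: 20 nM
- compound 3 `COc1ccccc1N1CCN(CCCNC(=O)NN(Cc2ccccc2F)c2ccc(F)cc2)CC1`: 3.6 nM

For the measured compounds named here, in an assay on CHO cells for displacement of a labelled ligand from D(4) dopamine receptor (Homo sapiens), read by radioligand binding (on this read-out higher numbers stand for weaker inhibition and lower numbers for stronger inhibition), compound 3 gives the lowest number of the three, beyond the scatter against both compound 2 and compound 1, so it is the most potent compound measured so far. Compound 4 `COc1ccccc1N1CCN(CCCNC(=O)NN(Cc2ccc(F)cc2)c2ccc(F)cc2)CC1` is not yet measured. It differs from compound 3 in one place: 4-fluorophenyl in place of 2-fluorophenyl on a saturated chain carbon bound to a nitrogen on an aromatic ring. Going by the values given here, no step of this kind between measured compounds exists here, so its size is open. The expectation is a small change, likely none beyond the scatter, in either direction; a 1.3-fold higher number from compound 3 to compound 4 (0.10 log units; within the scatter) is the estimated step. For compound 4 the estimate in this assay is 4.5 nM, with a range from 1.5 nM to 14 nM.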

Compound 4, inhibition constant: 4.6 nM
The estimate for compound 4 lay 1.0-fold (0.01 log units) below the measured number, within the range that was stated.
By their numbers in this assay, from the lowest: compounds 3 and 4 (each within the scatter of the next); then compounds 2 and 1 (each within the scatter of the next).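

In this assay, 4-fluorophenyl in place of 2-fluorophenyl on a saturated chain carbon bound to a nitrogen on an aromatic ring gives a 1.3-fold higher number from compound 3 to compound 4 (0.11 log units; within the scatter). For the compounds shown here, this is the first reading at this position, and the read-out does not separate 2-fluorobenzyl from 4-fluorobenzyl here. Nothing measured here offers an explanation for this result.

Still open, on these data alone, is whether unsubstituted benzyl or 4-chlorobenzyl at this place would give numbers in the same range. A longer chain, such as 2-phenylethyl, in place of the benzyl group also remains to be read.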